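Dropping the Carboxy Group: What to Expect for Compound 3

The compounds below may be only part of what the source reports. "The series", "measured", "known", "first", "only" and "open" are said of these compounds alone.

Compound 1, `COc1ccc(-c2nc3cc(Cl)c(Cl)cc3[nH]2)cc1`: 1000 nM
Compound 2, `O=C(O)CCC(=O)Nc1ccc(-c2nc3cc(C(F)(F)F)ccc3[nH]2)cc1`: > 100000 nM

In an ADME assay on MT4 cells (Homo sapiens) for cytotoxicity, read by MTT assay, with a stated time of 96 h (a lower number here means that less compound is tolerated, a higher number that more compound is tolerated), compound 1 gives 1000 nM. Compound 2 gives > 100000 nM, which is a limit of this assay rather than a measured number. Compound 2 therefore stands at the well-tolerated end of the numbers shown, as told by the limit of > 100000 nM in this assay, at which 1 of the 2 values shown sits.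

Compound 3, `CCC(=O)Nc1ccc(-c2nc3cc(C(F)(F)F)ccc3[nH]2)cc1`, has not yet been measured in this assay. It differs from compound 2 in one place: hydrogen in place of carboxy on a saturated chain carbon, two bonds along the chain from a carbonyl carbon. For the measured compounds named here, no step between two measured compounds is available here, so only an expectation can be given. Compound 3 is expected to give 80000 nM, with a range from 30000 nM to 200000 nM. The expected step of an at least 1.2-fold lower number from compound 2 to compound 3 (0.09 log units; that floor lies within the scatter) is small, within the usual scatter, and the reading for compound 3 may again come back only as a limit.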

Compound 3, half-maximal cytotoxic concentration: >= 100000 nM
Compound 3: only a limit was reported; the forecaster's own chance of this, stated with the estimate: 55%; middle value at least 1.2-fold (0.09 log units) away from the limit.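

In this assay, compound 2 and compound 3 both come back only as limits, so the step between them cannot be read. The compounds shown leave open where either half-maximal cytotoxic concentration truly lies, and whether hydrogen in place of carboxy changes tolerance at all.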